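A few compounds are considered here, and "the series" means these few. Any claim that something is new, unique, unknown or untested is made for them only; others in the source may bear on it.

Within the data shown here, compound 2 `CC(C)(C)c1cc(NC(=O)Nc2ccc(-c3cc4ccccc4o3)cc2)no1` gives the higher of the two numbers so far: in a functional assay on MV4-11 cells (Homo sapiens) for cytotoxicity, read by MTT assay, with a stated time of 72 h (a higher number here means a weaker inhibitor, a lower number a stronger inhibitor), compound 2 gives 195 nM, whereas compound 1 `CC(C)(C)c1cc(NC(=O)Nc2ccc(-c3cn4ccncc4n3)cc2)no1` gives 44.8 nM. Among the measured compounds shown here, the one measured step at this position, a 4.4-fold higher number from compound 1 to compound 2 (0.64 log units; beyond the scatter), shows that exchanging the bicyclic group changes the number by a modest amount. Compound 3 `CC(C)(C)c1cc(NC(=O)Nc2ccc(-c3nc4ccccc4s3)cc2)no1` carries 1,3-benzothiazol-2-yl in place of 1-benzofuran-2-yl on an aromatic carbon. For the measured compounds named here, no measured step covers this exact exchange, so only a small change is expected, a 1.5-fold lower number from compound 2 to compound 3 (0.18 log units; within the scatter). The number for compound 3 is therefore estimated at 130 nM, within a range from 45 nM to 400 nM.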

Compound 3, half-maximal inhibitory concentration: 172 nM
Compound 3: middle estimate off by 1.3-fold (0.12 log units), on the low side, within the range that was stated.
By their numbers in this assay, from the lowest: compound 1; then compounds 3 and 2 (each within the scatter of the next).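

In this assay, 1,3-benzothiazol-2-yl and 1-benzofuran-2-yl cannot be told apart at this position (a 1.1-fold lower number from compound 2 to compound 3 (0.05 log units; within the scatter)), so exchanging the oxygen-containing five-membered ring for one with nitrogen and sulfur gives no resolved change. The imidazole-type bicyclic group of the first compound stays separate from this second bicyclic group as well (a 3.8-fold higher number from compound 1 to compound 3 (0.58 log units; beyond the scatter)), matching the earlier step to the benzofuran. No measurement on hand offers an explanation for these results. Still open, as far as these compounds go, is whether a single ring such as phenyl, or a bicyclic group carrying an amine, would hold the lower number of compound 1.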